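From Compound 2 to Compound 3: Bromo to Trifluoromethyl

The source may report more compounds than this note shows. Statements on the series, on what has been measured and on what is new or still open speak of the compounds shown alone.

Going by the values given here, compound 2 `CS(=O)(=O)Nc1ccc(NC(=O)Nc2cccc(-c3nc(-c4ccc(NC(=O)c5cccnc5)cc4Cl)no3)c2)cc1Br` gives 700 nM in a functional assay on MDA-MB-231 cells (Homo sapiens) for antiproliferative activity, read by MTT assay, with a stated time of 72 h (on this read-out lower numbers stand for stronger inhibition and higher numbers for weaker inhibition), the lowest of the two numbers measured so far; compound 1 `COc1ccc(NC(=O)Nc2cccc(-c3nc(-c4ccc(NC(=O)c5cccnc5)cc4Cl)no3)c2)cc1C(F)(F)F` gives 1700 nM, and a 2.4-fold lower number from compound 1 to compound 2 (0.39 log units; beyond the scatter). Compound 3 `CS(=O)(=O)Nc1ccc(NC(=O)Nc2cccc(-c3nc(-c4ccc(NC(=O)c5cccnc5)cc4Cl)no3)c2)cc1C(F)(F)F` differs from compound 2 by trifluoromethyl in place of bromo on an aromatic carbon. Among the compounds with values here, no measured step isolates this exchange: the only step, a 2.4-fold lower number from compound 1 to compound 2 (0.39 log units; beyond the scatter), replaced the whole aryl group at once, and compound 1 already carries trifluoromethyl. The resulting step is therefore expected to be small, a 1.1-fold higher number from compound 2 to compound 3 (0.06 log units; within the scatter), with no clear direction. Compound 3 is estimated at 800 nM, between 350 nM and 2000 nM.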

Compound 3, half-maximal inhibitory concentration: 700 nM
Compound 3: the middle estimate sits 1.1-fold (0.06 log units) above what was measured, and the stated range covers the measured number.
By their numbers in this assay, from the lowest: compounds 2 and 3 (each within the scatter of the next); then compound 1.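

In this assay, the exchange of bromo for trifluoromethyl on this aromatic carbon, ortho to a methanesulfonamido group, gives no change at the digits printed from compound 2 to compound 3 (within the scatter) and so does not separate the two groups. With trifluoromethyl held in common, methanesulfonamido in place of methoxy gives a 2.4-fold lower number from compound 1 to compound 3 (0.39 log units; beyond the scatter) as a single change, which the earlier replacement of the whole aryl group could not isolate. No evidence bears on why either step came out as it did. The compounds shown leave open how chloro, methyl or an amine on this carbon would compare, and whether a carboxylic acid or a longer chain could stand in place of the methanesulfonamido group.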